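The compounds below may be only part of what the source reports. "The series", "measured", "known", "first", "only" and "open" are said of these compounds alone.

In a functional assay on MGC-803 cells (Homo sapiens) for antiproliferative activity, read by CCK-8 assay, with a stated time of 72 h (a higher number here means a weaker inhibitor, a lower number a stronger inhibitor), compound 3 `CCc1ccc(OCc2ccc(C(=O)Nc3ccccc3N)cc2)cc1`, which carries an ethyl group, gives 5880 nM. Compound 2 `Nc1ccccc1NC(=O)c1ccc(COc2ccccc2)cc1`, with hydrogen in place of that ethyl, gives 5670 nM, level with compound 3. Compound 1 `Nc1ccccc1NC(=O)c1ccc(COc2ccc(Cl)cc2)cc1`, with chloro instead, reads > 32000 nM, which is a limit of the assay and not a number. The chloro steps, an at least 5.6-fold lower number from compound 1 to compound 2 (0.75 log units; beyond the scatter) and an at least 5.4-fold lower number from compound 1 to compound 3 (0.73 log units; beyond the scatter), lie beyond the scatter but do not involve a change within the chain. Compound 4 `Cc1ccc(OCc2ccc(C(=O)Nc3ccccc3N)cc2)cc1` differs from compound 3 by hydrogen in place of methyl on a saturated chain carbon bound to an aromatic carbon, with hydrogen in place of methyl on a saturated chain carbon bound to an aromatic carbon, turning ethyl into methyl. Among the compounds with values here, no step beyond the scatter is expected in this assay because a 1.0-fold higher number from compound 2 to compound 3 (0.02 log units; within the scatter) is the closest precedent, from hydrogen to ethyl. The estimated change is a 1.1-fold lower number from compound 3 to compound 4 (0.03 log units; within the scatter). For compound 4 the expected value is 5500 nM, with an estimated range of 2800 nM to 11000 nM.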

Compound 4, half-maximal inhibitory concentration: 6530 nM
Estimate against measurement, compound 4: 1.2-fold (0.07 log units) below, within the range that was stated.
By their numbers in this assay, from the lowest: compounds 2, 3 and 4 (each within the scatter of the next). At a limit, above all of these: compound 1.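

In this assay the change from 4-ethylphenyl to 4-methylphenyl stays within the scatter (a 1.1-fold higher number from compound 3 to compound 4 (0.05 log units; within the scatter)), and the methyl group also reads level with hydrogen (a 1.2-fold higher number from compound 2 to compound 4 (0.06 log units; within the scatter)). Hydrogen, methyl and ethyl therefore read alike in these compounds, whereas chloro, in compound 1, goes against that pattern (an at least 4.9-fold lower number from compound 1 to compound 4 (0.69 log units; beyond the scatter)). The value of compound 1 is a limit of the assay and not a number: the limit of > 32000 nM in this assay, at which 1 of the 4 values shown sits. On these data alone, whether a longer chain, a methoxy group or an amine in this place would also read level with these compounds stays open.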